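Swapping one five-membered ring on the shared core

This account rests on a few compounds, and the source may have more. Where it says the series, first, only, none or still open, it means among the compounds named here.

In a functional assay on MV4-11 cells (Homo sapiens) for antiproliferative activity, read by luminescence, with a stated time of 72 h (a higher number here means a weaker inhibitor, a lower number a stronger inhibitor), compound 1 `Oc1ccc(COn2nnc3ccccc32)c2cccnc12` gives 12700 nM and compound 2 `Oc1ccc(Cn2cncn2)c2cccnc12` gives 5200 nM as the lower of the two numbers. Compound 3 `Oc1ccc(Cn2cccn2)c2cccnc12` carries 1H-pyrazol-1-yl in place of 1H-1,2,4-triazol-1-yl on a saturated chain carbon bound to an aromatic carbon. For the measured compounds named here, no measured pair shows this swap on its own, so the guess stays close to compound 2 at 5200 nM in value. The expected step of a 1.1-fold higher number from compound 2 to compound 3 (0.02 log units; within the scatter) is small and stays within the usual scatter, with no clear direction. For compound 3 the estimated value is 5500 nM with an expected range from 2300 nM to 13000 nM in this measurement.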

Compound 3, half-maximal inhibitory concentration: 1600 nM
Beside the measured number, compound 3's estimate is 3.4-fold (0.54 log units) above it; measured number outside the range, below it.
By their numbers in this assay, from the lowest: compound 3; then compound 2; then compound 1.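

On a saturated chain carbon bound to an aromatic carbon, the choice of five-membered aromatic ring clearly affects the result in this assay. Putting 1H-pyrazol-1-yl in place of 1H-1,2,4-triazol-1-yl gives a 3.3-fold lower number from compound 2 to compound 3 (0.51 log units; beyond the scatter) even though the change is small: one ring nitrogen becomes a carbon, and the heavy-atom count stays the same. Nothing available here explains this step. On these data alone, whether 1H-imidazol-1-yl or an amine such as morpholine would lower the number further on the same carbon remains open. So does whether the step would hold on a different core.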